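The source may report more compounds than this note shows. Statements on the series, on what has been measured and on what is new or still open speak of the compounds shown alone.

Measured compounds:
Compound 1, `CCCCCCCCC(=O)NCC(C)(C)CC1=C(O)C(=O)c2ccccc2C1=O`, gives 19700 nM in a functional assay on KB cells (Homo sapiens) for cytotoxicity, read by resazurin assay, with a stated time of 3 days; a lower number here means a stronger inhibitor, a higher number a weaker inhibitor.
Compound 2, `CCCCCCCCCC(=O)NCC(C)(C)CC1=C(O)C(=O)c2ccccc2C1=O`, gives 18500 nM in this assay.
Compound 3, `CCCCCCCCCC(=O)OCC(C)(C)CC1=C(O)C(=O)c2ccccc2C1=O`, gives 55500 nM in this assay.

Compounds 1 and 2 share a core and differ only by methyl in place of hydrogen on a saturated chain carbon, eight bonds along the chain from a carbonyl carbon. That change made a 1.1-fold lower number from compound 1 to compound 2 (0.03 log units; within the scatter), so the two cannot be told apart in this assay. Compound 3 carries a different core; how the core of compound 3 differs from the core of compound 1 is not broken down here. In this assay compound 3 stands as the highest of the three numbers, beyond the scatter from both compound 1 and compound 2.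

Compound 4, `CCCCCCCCCCC(=O)OCC(C)(C)CC1=C(O)C(=O)c2ccccc2C1=O`, has not yet been measured. It differs from compound 3 by methyl in place of hydrogen on a saturated chain carbon, nine bonds along the chain from a carbonyl carbon. For the measured compounds named here, this is the same kind of change as the one from compound 1 to compound 2, but not the same: there the added methyl sits eight bonds along the chain from a carbonyl carbon, here nine bonds along the chain from a carbonyl carbon, and the two cores differ. Going by the values given here, the only evidence about adding one carbon to the chain is the step from compound 1 to compound 2, which stayed within the scatter. On that basis the step from compound 3 to compound 4 in this assay is expected to be a 1.1-fold lower number from compound 3 to compound 4 (0.05 log units; within the scatter), small in the same way. Compound 4 is therefore estimated at 50000 nM in this assay. Among the compounds with values here, a range from 25000 nM to 100000 nM is expected for compound 4, wide because only one comparable step, a 1.1-fold lower number from compound 1 to compound 2 (0.03 log units; within the scatter), is known and it comes from a different core.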

Compound 4, half-maximal inhibitory concentration: 54800 nM
Compound 4: middle estimate off by 1.1-fold (0.04 log units), on the low side, and the stated range covers the measured number.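

Replacing a hydrogen with a methyl on a saturated chain carbon, nine bonds along the chain from a carbonyl carbon, gave a 1.0-fold lower number from compound 3 to compound 4 (0.01 log units; within the scatter) in this assay, so this small extension of the chain produced no change that can be distinguished from ordinary assay scatter. Set beside the earlier step on the core of compound 1, the same kind of change carried over from one core to the other without a detectable difference: the same change on two cores in this assay, a 1.1-fold lower number (0.03 log units; within the scatter) from compound 1 to compound 2 and a 1.0-fold lower number (0.01 log units; within the scatter) from compound 3 to compound 4, 1.1-fold (0.02 log units) apart, within the scatter of two such steps. For the compounds shown here, this shows that, for these two pairs, a newcomer to the series could have used the step on one core as a fair guide to the step on the other, but it rests on only two small steps, both too small to read clearly, and it does not show that a change with a larger effect would carry over in the same way, or that a third core would behave alike.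

The compounds shown leave open whether a much longer chain would finally move the number in either direction on these two cores. They also leave open whether a different group on the chain, such as an amine or a carboxylic acid, would have a larger effect and whether that effect would match from core to core.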